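The compounds below may be only part of what the source reports. "The series", "measured", "known", "first", "only" and "open" are said of these compounds alone.

Measured compounds in a functional assay for inhibition, with Homo sapiens as the target; on this read-out lower numbers stand for stronger inhibition and higher numbers for weaker inhibition:

Compound 1, `CCCc1nc(C)c2cnnc(SCC(=O)OCC)n12` — it gives > 48000 nM, which is a limit of the assay and not a number.
Compound 2, `CCOC(=O)CSc1nncc2c(C)nc(C)n12` — it gives > 48000 nM, again a limit of the assay and not a number.
Compound 3, `Cc1ncn2c(O)nncc12` — it gives > 48000 nM, once more a limit of the assay and not a number.

Among the measured compounds shown here, all three measured values therefore sit at the limit of > 48000 nM in this assay, at which 3 of the 3 values shown sit; none of them is a read number, and no compound can be set above or below another on this read-out. For the measured compounds named here, the only pair that differs in one place is compound 2 and compound 1: the change between them is ethyl in place of hydrogen on a saturated chain carbon bound to an aromatic carbon, and the step that the two limits leave unreadable from compound 2 to compound 1 cannot be sized, since both ends are limits.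

Compound 4, `CCCc1ncn2c(O)nncc12`, has not yet been measured. It differs from compound 3 by ethyl in place of hydrogen on a saturated chain carbon bound to an aromatic carbon, the same change at the same place as that from compound 2 to compound 1. The difference between the core of compound 3 and the core of compound 2 is not broken down here.

What can be expected for compound 4 rests on little. Because the earlier instance of this change left compound 1 at the limit of > 48000 nM in this assay, at which 3 of the 3 values shown sit, and compound 3 itself sits at the limit of > 48000 nM in this assay, at which 3 of the 3 values shown sit, the step from compound 3 to compound 4 is estimated to be about a step that the limit leaves unreadable from compound 3 to compound 4 in this assay. Compound 4 is accordingly expected to come out near 60000 nM, somewhere between 20000 nM and 200000 nM, and most probably the assay will again report only a limit for it rather than a number.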

Compound 4, half-maximal inhibitory concentration: > 48000 nM
Compound 4 ended at the assay's limit; the forecaster's own chance of this, stated with the estimate: 85%; the middle value lies beyond the limit too.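

Compound 3 and compound 4 both stand at a limit of this assay and not at a number, and the step between them, ethyl in place of hydrogen on a saturated chain carbon bound to an aromatic carbon, cannot be read. The same holds for all the compounds shown: the limit of > 48000 nM in this assay, at which 4 of the 4 values shown sit.
The compounds shown leave open whether this change alters inhibition at all, and how strongly any of them inhibits.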